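Benzyl Substituent Change on a Nucleoside Transporter Inhibitor

The source may hold more compounds than are shown below. What is called first, only, known or untested is meant among the compounds shown, and "the series" means these compounds.

Compound 2 `N#Cc1ccc(CSc2ncnc3c2ncn3[C@@H]2O[C@H](CO)[C@@H](O)[C@H]2O)cc1` gives 4.57 nM in an assay on isolated protein for inhibition of Equilibrative nucleoside transporter 1 (Homo sapiens) (on this read-out lower numbers stand for stronger inhibition and higher numbers for weaker inhibition), the lowest of the two numbers recorded, with compound 1 `OC[C@H]1O[C@@H](n2cnc3c(SCc4ccccc4I)ncnc32)[C@H](O)[C@@H]1O` nearest at 19.5 nM. Among the compounds with values here, the step of a 4.3-fold lower number from compound 1 to compound 2 (0.63 log units; beyond the scatter) is the only measured step, and it involves a different pair of groups at the same place than the one now in question. Compound 3 `Cc1cccc(CSc2ncnc3c2ncn3[C@@H]2O[C@H](CO)[C@@H](O)[C@H]2O)c1` differs from compound 2 by 3-methylphenyl in place of 4-cyanophenyl on a saturated chain carbon bound to a sulfur. Within the data shown here, no measured step compares a 3-methylphenyl with a 4-cyanophenyl, so the measured data give no direct guide to direction. Since both measured compounds sit in a fairly narrow band and both replacements change the group on a saturated chain carbon bound to a sulfur, the expectation is that compound 3 stays within that band, with a modest rise of a 2.2-fold higher number from compound 2 to compound 3 (0.34 log units; beyond the scatter) toward the middle of the measured values being the likelier outcome. Compound 3 is therefore estimated at 10 nM in this assay, with a range from 3 nM to 35 nM.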

Compound 3, inhibition constant: 16.2 nM
For compound 3 the middle estimate is 1.6-fold (0.21 log units) below the measured one, and the stated range covers the measured number.
By their numbers in this assay, from the lowest: compound 2; then compounds 3 and 1 (each within the scatter of the next).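

In this assay, the swap of 4-cyanophenyl for 3-methylphenyl on a saturated chain carbon bound to a sulfur gives a 3.5-fold higher number from compound 2 to compound 3 (0.55 log units; beyond the scatter), which means that the earlier advantage of compound 2 over compound 1 is now seen against a second group as well. The comparison with the 2-iodophenyl compound gives a 1.2-fold lower number from compound 1 to compound 3 (0.08 log units; within the scatter), so 3-methylphenyl and 2-iodophenyl cannot be told apart at this position, even though they differ in both substituent and ring placement, and only compound 2, with its 4-cyanophenyl group, stands clear of the other two, with steps to both beyond the scatter. Nothing available here accounts for this difference.

The 4-cyanophenyl and 3-methylphenyl groups differ in both the substituent and its numbered ring place, so these compounds cannot show whether the nitrile or its placing carries the step, a question that 3-cyanophenyl and 4-methylphenyl groups would separate. From the compounds shown here alone, how a 4-aminophenyl or 4-carboxyphenyl group, or a longer chain between the sulfur and the ring, would read in this assay also remains open.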